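Methyl on the sulfonyl aryl ring in the shared core series

This account rests on a few compounds, and the source may have more. Where it says the series, first, only, none or still open, it means among the compounds named here.

Three compounds with the same core have numbers in a functional assay on MCF7 cells (Homo sapiens) for cytotoxicity, read by MTT assay, with a stated time of 48 h; a lower number here means a stronger inhibitor, a higher number a weaker inhibitor. Compound 1 `COc1ccc(N)cc1-c1cnc2[nH]cc(-c3ccncc3)c2c1` gives 5400 nM. Compound 2 `CC(=O)Nc1cccc(-c2cnc3[nH]cc(-c4ccncc4)c3c2)c1` gives 9100 nM. Compound 3 `Nc1cc(NS(=O)(=O)c2ccccc2)cc(-c2cnc3[nH]cc(-c4ccncc4)c3c2)c1` gives 8800 nM; it stands second highest of the three numbers, but its gap to compound 2 and its gap to compound 1 both lie within the scatter, so no order among the three can be read from these values. Compound 4 `Cc1ccc(S(=O)(=O)Nc2cc(N)cc(-c3cnc4[nH]cc(-c5ccncc5)c4c3)c2)cc1` differs from compound 3 by methyl in place of hydrogen on an aromatic carbon. Going by the values given here, no pair of measured compounds shows this change, so no step beyond the scatter is expected in this assay, in either direction; the step from compound 3 to compound 4 is estimated at a 1.1-fold lower number from compound 3 to compound 4 (0.04 log units; within the scatter). Compound 4 is expected to give about 8000 nM, with a range from 3500 nM to 18000 nM.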

Compound 4, half-maximal inhibitory concentration: 10400 nM
Compound 4: the middle estimate sits 1.3-fold (0.11 log units) below what was measured; low and high end bracket the measured number.
By their numbers in this assay, from the lowest: compounds 1, 3, 2 and 4 (each within the scatter of the next).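

In this assay, going by these compounds alone, the change from phenylsulfonyl to (4-methylphenyl)sulfonyl gives a 1.2-fold higher number from compound 3 to compound 4 (0.07 log units; within the scatter) and is the first one-place comparison. At this single position, para to a large group, methyl in place of hydrogen therefore produces no step beyond the scatter. No measurement here bears on the reason for this step.

Going by these compounds, whether an amine, a carboxylic acid or a longer chain at this position would give a step beyond the scatter remains open. The same holds for methyl on the other aromatic carbons of this ring.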